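Fluorine on the anilino ring of a triazine series

The source may hold more compounds than are shown below. What is called first, only, known or untested is meant among the compounds shown, and "the series" means these compounds.

Of the compounds shown here, three built on a shared core have been measured in an assay on cells for activation of Cystic fibrosis transmembrane conductance regulator (Homo sapiens), read by fluorescence, with stated times of 10 min and 12 s; a lower number here means that less compound is needed, a higher number that more compound is needed for the effect. Compound 1 `CCN(CC)c1nc(Nc2ccc(C(=O)O)cc2)nc(OC(C(F)(F)F)C(F)(F)F)n1` gives 900 nM, compound 2 `CCN(CC)c1nc(Nc2ccc3[nH]ncc3c2)nc(OC(C(F)(F)F)C(F)(F)F)n1` gives 2800 nM, and compound 3 `CCN(CC)c1nc(Nc2ccccc2)nc(OCC(F)(F)C(F)F)n1` gives 2000 nM. Within these three numbers compound 3 stands second highest: compound 2 sits nearest to it and the gap falls within the usual scatter, while compound 1 is furthest away, with a lower number beyond the scatter.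

Compound 4 `CCN(CC)c1nc(Nc2ccc(F)cc2)nc(OCC(F)(F)C(F)F)n1` differs from compound 3 in one place: fluoro in place of hydrogen on an aromatic carbon, on an aromatic carbon of a six-membered aromatic ring of carbon only, para to a large group. Among the compounds with values here, only one single-point step has been measured so far, a 3.1-fold higher number from compound 1 to compound 2 (0.49 log units; beyond the scatter), and it swaps one aryl group on the nitrogen for another rather than adding a single fluorine to a ring, so it bears on the present change only loosely. Within the data shown here, that step was modest, and there is no measured example of a fluoro for hydrogen swap in this set. A step of no more than the scatter is therefore expected in this assay, in no definite direction.

Compound 4 is estimated at 1800 nM, with a range from 800 nM to 4000 nM, which means an expected step of a 1.1-fold lower number from compound 3 to compound 4 (0.05 log units; within the scatter).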

Compound 4, half-maximal effective concentration: 4800 nM
Compound 4: the middle estimate sits 2.7-fold (0.43 log units) below what was measured; measured number outside the range, above it.
By their numbers in this assay, from the lowest: compound 1; then compounds 3, 2 and 4 (each within the scatter of the next, the first and the last beyond it).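

Putting one fluoro in place of hydrogen on the aromatic ring, para to a large group, is not a silent change in this assay: turning the phenyl into 4-fluorophenyl gives a 2.4-fold higher number from compound 3 to compound 4 (0.38 log units; beyond the scatter), so more compound is needed for the effect. The earlier step exchanged one whole aryl group for another, whereas here a single added atom at this place on the ring is enough to move the number beyond the usual scatter. Within the data shown here, nothing measured so far shows why the number rises with this swap.

Going by these compounds, whether a larger group at the same place, such as chloro, methyl or methoxy, would also raise the number remains open, as does whether a carboxylic acid there would lower it on this chain as it might be expected to from compound 1 alone. On these data alone, it is also open whether the same fluoro for hydrogen swap would have a step of this size on the core of compound 1, which carries a different chain on the oxygen.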